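A few compounds are considered here, and "the series" means these few. Any claim that something is new, unique, unknown or untested is made for them only; others in the source may bear on it.

Compound 3, `CCN[C@H](c1cc(C(F)(F)F)ccc1N1CCN(C(=O)CCc2ccc(Cl)cc2Cl)CC1)C(C)CC`, sits second highest among the three numbers recorded so far: in an assay on HEK293 cells for displacement of a labelled ligand from Melanocortin receptor 4 (Homo sapiens) (a lower number here means a stronger inhibitor, a higher number a weaker inhibitor), compound 3 gives 92 nM. Its nearest neighbour is compound 1, `CCC(C)[C@H](N)c1cc(C(F)(F)F)ccc1N1CCN(C(=O)CCc2ccc(OC)cc2Cl)CC1`, which in this assay gives 57 nM, a gap that lies within the scatter. Far from both stands compound 2, `COc1cc(OC)c(OC)cc1CCC(=O)N1CCN(c2ccc(C(F)(F)F)cc2[C@@H](N)CC(C)C)CC1`, which in this assay gives 6100 nM.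

The next compound, compound 4, `CCC(C)[C@H](NC(C)=O)c1cc(C(F)(F)F)ccc1N1CCN(C(=O)CCc2ccc(Cl)cc2Cl)CC1`, is not yet measured. It differs from compound 3 in one place: acetyl in place of ethyl on an amine nitrogen. For the measured compounds named here, both measured compounds at the low end, compound 1 and compound 3, carry a free amine at that position; no measured compound carries an acetyl there, so the data give no direct guide to the size of this step.

With an acceptor replacing a plain ethyl on the amine nitrogen, the change is expected to move the number upward, toward weaker binding, by more than the scatter. The step from compound 3 to compound 4 is estimated at a 6.5-fold higher number from compound 3 to compound 4 (0.81 log units; beyond the scatter). Compound 4 is accordingly expected to give about 600 nM in this assay, with a plausible range from 150 nM to 3000 nM.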

Compound 4, inhibition constant: 360 nM
Beside the measured number, compound 4's estimate is 1.7-fold (0.22 log units) above it; the measured number falls inside the stated range.
By their numbers in this assay, from the lowest: compounds 1 and 3 (each within the scatter of the next); then compound 4; then compound 2.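

For the compounds shown here, compound 3 and compound 4 form the first pair here that differs in one place only, so they give the first direct reading of the amine nitrogen in this assay: acetyl in place of ethyl gives a 3.9-fold higher number from compound 3 to compound 4 (0.59 log units; beyond the scatter) at this position. The nitrogen therefore responds to this exchange by more than the scatter, though the step is modest, and with the acetamido group compound 4 still gives a measured number of 360 nM in this assay, so this substituent is tolerated to that extent. Nothing measured alongside these compounds accounts for the step, and the pair alone cannot separate the contribution of the carbonyl from that of the added atom in the group that enters.

The compounds shown leave open how other groups on this nitrogen would read, such as a methyl, a longer chain like propyl, or a methanesulfonyl group, and so whether the step follows the carbonyl or the size of the group. They also leave open whether the same exchange would give a step of similar size with a different acyl part on the far side of the molecule, as in compound 1 or compound 2.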